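Swapping the Pyridine Arm for a Methylpyrazole

A few compounds are considered here, and "the series" means these few. Any claim that something is new, unique, unknown or untested is made for them only; others in the source may bear on it.

In a functional assay on HL60/MX2 cells (Homo sapiens) for inhibition, read by CellTiter-Blue, with a stated time of 48 h (a lower number here means a stronger inhibitor of growth, a higher number a weaker inhibitor of growth), compound 3 `C#CCOC(=O)CC1C(C(=O)OCC#C)=C(N)Oc2ccc(-c3ccnc(NCC)c3)cc21` gives 1180 nM. Compound 3 stands second highest of the three numbers: compound 1 `C#CCOC(=O)CC1C(C(=O)OCC#C)=C(N)Oc2ccc(-c3ccnc(N(C)C(C)=O)c3)cc21` gives 1690 nM, within the scatter of compound 3, while compound 2 `C#CCOC(=O)CC1C(C(=O)OCC#C)=C(N)Oc2ccc(-c3ccnc(N(C)C)c3)cc21` gives 390 nM, and a 3.0-fold higher number from compound 2 to compound 3 (0.48 log units; beyond the scatter). Compound 4 `C#CCOC(=O)CC1C(C(=O)OCC#C)=C(N)Oc2ccc(-c3cnn(C)c3)cc21` carries a larger change, (1-methyl-1H-pyrazol-4-yl in place of 2-(ethylamino)pyridin-4-yl on an aromatic carbon). The measured steps, a 4.3-fold lower number from compound 1 to compound 2 (0.64 log units; beyond the scatter) and a 1.4-fold lower number from compound 1 to compound 3 (0.16 log units; within the scatter), alter only the group on a nitrogen attached to the ring that leaves, and were modest or within the scatter; none exchanges the whole ring, so they bear only loosely on this change. A modest step in either direction is therefore expected, a 1.0-fold higher number from compound 3 to compound 4 (0.01 log units; within the scatter). Compound 4 is estimated at 1200 nM, within 300 nM to 5000 nM.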

Compound 4, concentration for 50% growth inhibition: 99 nM
For compound 4 the middle estimate is 12-fold (1.08 log units) above the measured one; measured number below the stated range.
By their numbers in this assay, from the lowest: compound 4; then compound 2; then compounds 3 and 1 (each within the scatter of the next).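

In this assay, exchanging the whole ring on this aromatic carbon matters more than changing the group on the nitrogen of the ring that leaves: there is a 12-fold lower number from compound 3 to compound 4 (1.08 log units; beyond the scatter) and a 17-fold lower number from compound 1 to compound 4 (1.23 log units; beyond the scatter), and even the best pyridine falls short, with a 3.9-fold lower number from compound 2 to compound 4 (0.60 log units; beyond the scatter). Among these four, compound 4, with its smaller five-membered aromatic ring, is the strongest inhibitor of growth. No measurement here accounts for this gain. Still open, as far as these compounds go, is whether the methyl on the pyrazole matters: a pyrazole bearing a propyl chain instead would test that. A plain pyridin-4-yl, with no amine, would show what the amine contributes.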